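An Aryl Swap on the Carbonyl in an Inactive Set

The compounds below may be only part of what the source reports. "The series", "measured", "known", "first", "only" and "open" are said of these compounds alone.

Compound 1 `NC(=O)c1c(NC(=O)c2ccc(C(F)(F)F)cc2)sc2c1CCN(Cc1ccccc1F)C2`: in a functional assay on HeLa cells (Homo sapiens) for antiproliferative activity, with a stated time of 24 h (on this read-out lower numbers stand for stronger inhibition and higher numbers for weaker inhibition), compound 1 gives > 50000 nM, which is a limit of the assay.
Compound 2 `NC(=O)c1c(NC(=O)c2ccc(C(F)(F)F)cc2)sc2c1CCN(Cc1ccc(Cl)cc1)C2`: compound 2 gives > 50000 nM, again a limit.
Compound 3 `NC(=O)c1c(NC(=O)c2ccc(C(F)(F)F)cc2)sc2c1CCN(Cc1ccc(Cl)cc1Cl)C2`: compound 3 gives > 50000 nM, also a limit.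

All three measured compounds sit at the limit of > 50000 nM in this assay, at which 3 of the 3 values shown sit, so compound 3 stands at the limit and cannot be placed above or below its two companions. The steps a step that the two limits leave unreadable from compound 1 to compound 2, a step that the two limits leave unreadable from compound 1 to compound 3 and a step that the two limits leave unreadable from compound 2 to compound 3 are all unreadable, each running between two limits.

Compound 4 `NC(=O)c1c(NC(=O)c2cccc([N+](=O)[O-])c2)sc2c1CCN(Cc1ccc(Cl)cc1Cl)C2` differs from compound 3 by 3-nitrophenyl in place of 4-(trifluoromethyl)phenyl on a carbonyl carbon. For the measured compounds named here, none of the measured steps touches that carbonyl position; all three change the group on the saturated chain carbon bound to the amine nitrogen in the ring, and none yields a readable size. Going by the values given here, the step from compound 3 to compound 4 therefore has no measured precedent, and since compound 3 and its two neighbours all sit at the limit of > 50000 nM in this assay, at which 3 of the 3 values shown sit, compound 4 is expected most likely to remain at a limit as well, with an expected step of a number no higher from compound 3 to compound 4 (the limit leaves the size open). The estimate for compound 4 in this assay is 50000 nM, ranging from 15000 nM to 150000 nM.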

Compound 4, half-maximal inhibitory concentration: 33000 nM
The estimate for compound 4 lay 1.5-fold (0.18 log units) above the measured number, and the stated range covers the measured number.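

For the compounds shown here, on the carbonyl carbon whose other neighbours are amide-type nitrogen, 3-nitrophenyl in place of 4-(trifluoromethyl)phenyl gives an at least 1.5-fold lower number from compound 3 to compound 4 (0.18 log units; that floor lies within the scatter) in this assay and so provides the first step in the set with a readable floor. The earlier steps, all on the saturated chain carbon bound to an amine nitrogen in a ring, ran between limits and cannot be read, which makes the carbonyl position the only place shown where a change brings a compound off the limit. The floor of this step still lies within the usual scatter, so the shift is only weakly supported. Going by these compounds alone, compound 4 at 33000 nM remains the one readable number in the set. The other three compounds stay where they stood: the limit of > 50000 nM in this assay, at which 3 of the 4 values shown sit.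

The compounds shown leave open whether 3-nitrophenyl would also give a number with the 2-fluorophenyl or 4-chlorophenyl groups of compound 1 and compound 2 on the chain. They also leave open how a plain phenyl, an aminophenyl or a phenyl carrying a carboxylic acid would behave on the same carbonyl.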